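From cyclopropyl to 1-methylpiperidin-4-yl on an aromatic nitrogen

This account rests on a few compounds, and the source may have more. Where it says the series, first, only, none or still open, it means among the compounds named here.

Three compounds have values in an ADME assay on the whole organism (Mus musculus, strain ICR(CD-1)) for pharmacokinetics, read by mass spectrometry, at a dose of 10 mg/kg by the oral route; a higher number here means more compound in the circulation at the dose given, a lower number less compound in the circulation ( the values below are maximal plasma concentrations )
- compound 1 `Cc1ccc(C(=O)Nc2cccc(C(F)(F)F)c2)cc1-c1ccc2c(-c3ccc(N4CCN(C)CC4)cc3)n[nH]c2c1` gives 27.9 nM
- compound 2 `Cc1ccc(C(=O)Nc2cccc(C(F)(F)F)c2)cc1-c1ccc2c(-c3cnn(C)c3)n[nH]c2c1` gives 1870 nM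
- compound 3 `Cc1ccc(C(=O)Nc2cccc(C(F)(F)F)c2)cc1-c1ccc2c(-c3cnn(C4CC4)c3)n[nH]c2c1` gives 2240 nM

Compound 3 sits with compound 2 at the top of this small set. The two lie within the scatter of each other, and compound 1 stands far lower.

Compound 4 `Cc1ccc(C(=O)Nc2cccc(C(F)(F)F)c2)cc1-c1ccc2c(-c3cnn(C4CCN(C)CC4)c3)n[nH]c2c1` carries 1-methylpiperidin-4-yl in place of cyclopropyl on an aromatic nitrogen. Going by the values given here, the one measured step at this place (a 1.2-fold higher number from compound 2 to compound 3 (0.08 log units; within the scatter)) put cyclopropyl in place of methyl and stayed within the scatter, but the group entering now is much larger, so that step is a weak guide. Compound 1 also holds a six-membered non-aromatic ring with nitrogen, on a different substituent, and a reason for caution is the value of compound 1 (27.9 nM) in this assay. The data do not show whether that ring accounts for the gap. A fall beyond the scatter is therefore expected, though probably not the full distance to compound 1. The estimated change is a 6.4-fold lower number from compound 3 to compound 4 (0.81 log units; beyond the scatter) in this read-out. For compound 4 the expected value is 350 nM, with an estimated range from 60 nM to 1600 nM.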

Compound 4, maximal plasma concentration: 304 nM
Compound 4: the middle estimate sits 1.2-fold (0.06 log units) above what was measured, within the range that was stated.
By their numbers in this assay, from the lowest: compound 1; then compound 4; then compounds 2 and 3 (each within the scatter of the next).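

Methyl and cyclopropyl on this aromatic nitrogen had left this assay within the scatter (a 1.2-fold higher number from compound 2 to compound 3 (0.08 log units; within the scatter)), so the position had looked indifferent to what it carried, and compound 4 shows that it is not. With 1-methylpiperidin-4-yl the number falls beyond the scatter from either smaller group (a 7.4-fold lower number from compound 3 to compound 4 (0.87 log units; beyond the scatter); a 6.2-fold lower number from compound 2 to compound 4 (0.79 log units; beyond the scatter)), so the drop does not rest on a single comparison. Compound 4, at 304 nM, still stands above compound 1, at 27.9 nM, and among these compounds a six-membered non-aromatic ring with nitrogen occurs only in the two lowest, compound 1 and compound 4, though on different substituents.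

No measurement shown here explains this fall. The compounds shown do not separate the larger ring from its nitrogen, and a tetrahydropyran-4-yl or a plain cyclohexyl at this place, set against compound 4, would put that question to the test.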